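Swapping a difluorophenyl arm for a methyl-oxazole in a hydroxamate series

The compounds below may be only part of what the source reports. "The series", "measured", "known", "first", "only" and "open" are said of these compounds alone.

Measured compounds:
- compound 1, `COc1ccc(S(=O)(=O)N(Cc2cc(F)cc(F)c2)[C@H](C)C(=O)NO)cc1`: 140 nM
- compound 2, `COc1ccc(S(=O)(=O)N(Cc2ccccc2C(F)(F)F)[C@H](C)C(=O)NO)cc1`: 6 nM
- compound 3, `COc1ccc(S(=O)(=O)N(Cc2ccc(Cl)c([N+](=O)[O-])c2)[C@H](C)C(=O)NO)cc1`: 30 nM

Three hydroxamic acids sharing the same core were tested in an assay on isolated protein for inhibition of bone morphogenetic protein 1 (Homo sapiens); on this read-out higher numbers stand for weaker inhibition and lower numbers for stronger inhibition. Compound 1 stands at the highest number of the three, so it is the weakest inhibitor in this set. Its nearest neighbour is compound 3, which sits well outside the scatter at a lower number, and compound 2 lies furthest away, with the lowest number of the three. No two of these compounds differ in only one place, so the two lower values say only that other arms on the sulfonamide nitrogen can reach stronger inhibition than the arm of compound 1.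

Compound 4, `COc1ccc(S(=O)(=O)N(Cc2cc(C)on2)[C@H](C)C(=O)NO)cc1`, has not yet been measured. It is drawn from compound 1 by one change: 5-methyl-1,2-oxazol-3-yl in place of 3,5-difluorophenyl on a saturated chain carbon bound to a sulfonamide nitrogen. The group that enters is smaller and carries two hydrogen-bond acceptors where the group that leaves carries none. For the measured compounds named here, nothing among the measured compounds shows how this assay responds to such a swap, so the expected step from compound 1 to compound 4 is set at a 1.4-fold higher number from compound 1 to compound 4 (0.15 log units; within the scatter), roughly none beyond the scatter, with wide uncertainty in both directions. On that basis compound 4 is estimated at 200 nM, with a range from 50 nM to 900 nM.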

Compound 4, half-maximal inhibitory concentration: 230 nM
Compound 4: the middle estimate sits 1.2-fold (0.06 log units) below what was measured; measured number inside the range.
By their numbers in this assay, from the lowest: compound 2; then compound 3; then compounds 1 and 4 (each within the scatter of the next).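

In this assay, for the compounds shown here, placing 5-methyl-1,2-oxazol-3-yl in place of 3,5-difluorophenyl on a saturated chain carbon bound to a sulfonamide nitrogen gives a 1.6-fold higher number from compound 1 to compound 4 (0.22 log units; within the scatter), the first comparison in this set that isolates a change at this place, and it does not separate the two arms. At this place, then, the read-out stays within the scatter when a carbon-only six-membered aromatic ring with two fluorines gives way to a five-membered aromatic ring with 2 hetero atoms, 6 heavy atoms in place of 8, and 2 hydrogen-bond acceptors in place of none. No supporting data are available to explain this outcome.

Open, as far as these compounds go, is whether this result depends on the methyl of the new arm, which a plain 1,2-oxazol-3-yl arm or a 5-ethyl-1,2-oxazol-3-yl arm would test, and whether a pyridyl or an unsubstituted phenyl arm would also stay within the scatter of compound 1. Also open, from the compounds shown here alone, is whether the same swap would give a similar step when made on a core with a different group on the sulfonyl side.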